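The compounds below may be only part of what the source reports. "The series", "measured", "known", "first", "only" and "open" are said of these compounds alone.

Measured so far:
- compound 1, `CCCCCCCCCCCC(=O)OC[C@H](CSC[C@@H](N)C(=O)N[C@H](C)CO)OC(=O)CCCCCCCCCCC`: 22200 nM
- compound 2, `CCCCCCCCCCCC(=O)OC[C@H](CSC[C@@H](N)C(=O)NCCCCCCO)OC(=O)CCCCCCCCCCC`: 33 nM
- compound 3, `CCCCCCCCCCCC(=O)OC[C@H](CSC[C@@H](N)C(=O)NCCOCCOCCOCCC(=O)O)OC(=O)CCCCCCCCCCC`: 900 nM

All three share the same diacylated thioglycerol-cysteine core and differ only in the amide substituent. In an assay on HEK293 cells for agonist activity at Toll-like receptor 2 (Homo sapiens) (on this read-out higher numbers stand for an effect only at larger amounts of compound and lower numbers for an effect already at smaller amounts), compound 1 gives 22200 nM, the highest number of the set. The step of a 670-fold lower number from compound 1 to compound 2 (2.83 log units; beyond the scatter) shows that the amide substituent alone can move the number a long way. Compound 3 stands second highest of the three, well separated from both neighbours, with a 27-fold higher number from compound 2 to compound 3 (1.44 log units; beyond the scatter) marking the move from the best compound.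

Compound 4, `CCCCCCCCCCCC(=O)OC[C@H](CSC[C@@H](N)C(=O)NCCN)OC(=O)CCCCCCCCCCC`, has not been measured. It differs from compound 3 in one place: amino in place of 2-(2-(2-carboxyethoxy)ethoxy)ethoxy on a saturated chain carbon, two bonds along the chain from an amide-type nitrogen. The change undoes the long ether-acid chain that, in a 27-fold higher number from compound 2 to compound 3 (1.44 log units; beyond the scatter), brought a large rise in the number, and replaces it with a single nitrogen. Compound 2 shows that a short flexible chain ending in a donor-acceptor group sits at the low end of this set, while compound 1 shows that a short branched substituent sits at the high end. Since compound 4 carries a short unbranched chain, the expectation is a lower number than compound 3, with a 7.5-fold lower number from compound 3 to compound 4 (0.88 log units; beyond the scatter) of moderate size but wide uncertainty. For compound 4 the estimate is 120 nM, within 20 nM to 800 nM.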

Compound 4, half-maximal effective concentration: 5240 nM
Estimate against measurement, compound 4: 44-fold (1.64 log units) below; the whole stated range lies below it.
By their numbers in this assay, from the lowest: compound 2; then compound 3; then compound 4; then compound 1.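

In this assay, amino in place of 2-(2-(2-carboxyethoxy)ethoxy)ethoxy on a saturated chain carbon, two bonds along the chain from an amide-type nitrogen, gives a 5.8-fold higher number from compound 3 to compound 4 (0.77 log units; beyond the scatter), so at this position the shorter substituent does not give the lower number, and the long ether-acid chain of compound 3 outperforms amino. Amino in place of 4-hydroxybutyl at the same place gives a 160-fold higher number from compound 2 to compound 4 (2.20 log units; beyond the scatter), showing that the low number of compound 2 does not carry over to every unbranched substituent on the amide nitrogen, while 2-aminoethyl in place of 1-(hydroxymethyl)ethyl gives only a 4.2-fold lower number from compound 1 to compound 4 (0.63 log units; beyond the scatter), leaving compound 4 much nearer the high end of the series than its unbranched chain alone would suggest. No measurement at hand accounts for the direction or size of these steps.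

Chain length and terminal group change together from compound 2 to compound 4, so the contribution of each remains unresolved. A 6-aminohexyl or a 2-hydroxyethyl group on the amide nitrogen would separate the two, and a longer ether chain ending in a hydroxyl rather than a carboxylic acid would do the same for compound 3.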